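The compounds below may be only part of what the source reports. "The series", "measured", "known", "first", "only" and "open" are said of these compounds alone.

Three stereoisomers of one small nitrogen ring carrying a long chain have been tested in a functional assay on A549 cells (Homo sapiens) for cytotoxicity; on this read-out lower numbers stand for stronger inhibition and higher numbers for weaker inhibition. Compound 1 `CCCCCCCCCCCCCC[C@H]1N[C@H](CO)[C@H]1O` gives only a limit of the assay, > 2 ug/mL. Compound 2 `CCCCCCCCCCCCCC[C@H]1N[C@@H](CO)[C@H]1O` gives 1.38 ug/mL. Compound 3 `CCCCCCCCCCCCCC[C@@H]1N[C@H](CO)[C@@H]1O` likewise reaches only a limit, > 2 ug/mL. Its standing is thus known only as a boundary, the one at which two of the three values sit (the limit of > 2 ug/mL in this assay, at which 2 of the 3 values shown sit). Compound 4 `CCCCCCCCCCCCCC[C@@H]1N[C@H](CO)[C@H]1O` is a further isomer: the two compounds have the same atoms and bonds and differ only in configuration as drawn: 1 of 3 stereo elements differ; a stereocentre at a saturated ring carbon is drawn R in compound 3 and S in compound 4. A single inversion of this kind was seen before, an at least 1.4-fold lower number from compound 1 to compound 2 (0.16 log units; that floor lies within the scatter), and the mirror-image pair gave an at least 1.4-fold higher number from compound 2 to compound 3 (0.16 log units; that floor lies within the scatter); each rests on a limit and stays within the scatter. The step that the two limits leave unreadable from compound 1 to compound 3 adds nothing readable. No shift beyond the scatter is therefore expected, a step that the limit leaves unreadable from compound 3 to compound 4. Compound 4 is estimated at 2.5 ug/mL, between 1 ug/mL and 6 ug/mL.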

Compound 4, half-maximal inhibitory concentration: 1.97 ug/mL
Beside the measured number, compound 4's estimate is 1.3-fold (0.10 log units) above it; the measured number falls inside the stated range.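

In this assay compound 4 gives a measured number rather than a limit, yet inverting one ring carbon gives only an at least 1.0-fold lower number from compound 3 to compound 4 (0.00 log units; that floor lies within the scatter) and an at least 1.0-fold lower number from compound 1 to compound 4 (0.00 log units; that floor lies within the scatter). The only step between two measured numbers, a 1.4-fold higher number from compound 2 to compound 4 (0.15 log units; within the scatter), does not separate these isomers either, and it reflects configuration alone: the fact that compounds 2 and 4 differ only in the configuration as drawn

Going by these compounds, compound 1 and compound 3 stand only at a limit, so the true size of their steps stays open. Also open, on these data alone, is whether a longer chain would make the isomers differ.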